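The source may report more compounds than this note shows. Statements on the series, on what has been measured and on what is new or still open speak of the compounds shown alone.

In a functional assay on A549 cells (Homo sapiens) for cytotoxicity, read by MTT assay, with a stated time of 48 h (a lower number here means a stronger inhibitor, a higher number a weaker inhibitor), three compounds have been measured.
Compound 1 `COc1cc(-c2nnc3n2NC(c2ccco2)C(C(=O)c2cccc(Br)c2)S3)cc(OC)c1OC` gives 36900 nM.
Compound 2 `COc1cc(-c2nnc3n2NC(c2ccco2)C(C(=O)c2ccc(-c4ccccc4)cc2)S3)cc(OC)c1OC` sits at an assay limit, > 100000 nM.
Compound 3 `COc1cc(-c2nnc3n2NC(c2ccco2)C(C(=O)c2cccc4ccccc24)S3)cc(OC)c1OC` also sits at an assay limit, > 100000 nM.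

Compound 3 therefore stands at the limit of > 100000 nM in this assay, at which 2 of the 3 values shown sit, and no number is known for it. The step of an at least 2.7-fold higher number from compound 1 to compound 3 (0.43 log units; beyond the scatter) is a weakening that is at least modest, while a step that the two limits leave unreadable from compound 2 to compound 3 cannot be sized. The next compound, compound 4 `COc1cc(-c2nnc3n2NC(c2ccco2)C(C(=O)c2ccc([N+](=O)[O-])cc2)S3)cc(OC)c1OC`, differs from compound 3 by 4-nitrophenyl in place of naphthalen-1-yl on a carbonyl carbon. Since compound 1, which also carries a single ring on that carbonyl carbon, gives 36900 nM, compound 4 is expected to move back toward that value, by an estimated step of an at least 2.0-fold lower number from compound 3 to compound 4 (0.30 log units; that floor lies within the scatter). Compound 4 is estimated at 50000 nM, with a range from 15000 nM to 150000 nM.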

Compound 4, half-maximal inhibitory concentration: > 100000 nM
Compound 4 was reported as a limit; the forecaster's own chance of this, stated with the estimate: 40%; middle value at least 2.0-fold (0.30 log units) away from the limit.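

In this assay compound 4 gives only a limit, > 100000 nM, so a single ring on the carbonyl carbon does not by itself secure a measurable value. With 4-nitrophenyl in place of 3-bromophenyl, the change is an at least 2.7-fold higher number from compound 1 to compound 4 (0.43 log units; beyond the scatter), while the steps linking compound 4 to compound 2 and compound 3 cannot be read. Compound 1 remains the only one of these compounds with a number, and the others share a single ceiling: the limit of > 100000 nM in this assay, at which 3 of the 4 values shown sit.

Still open, on these data alone, is whether the bromine of compound 1 matters, or whether any other ring substituent would also give a number. A phenyl ring carrying an amine or a carboxylic acid on that carbonyl carbon could test this.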